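Replacing (ethoxycarbonyl)methyl with carboxy on compound 3

A few compounds are considered here, and "the series" means these few. Any claim that something is new, unique, unknown or untested is made for them only; others in the source may bear on it.

- Compound 1 `COc1ccccc1OCC1SCCN1C(C)=O` gives 46 mg/kg in a functional assay on the whole organism for inhibition, with Cavia porcellus as the target; on this read-out lower numbers stand for an effect already at smaller amounts and higher numbers for an effect only at larger amounts of compound
- Compound 2 `COc1ccccc1OCC1SCCN1C(=O)CC(C)=O` gives 30 mg/kg in this assay
- Compound 3 `CCOC(=O)CCC(=O)N1CCSC1COc1ccccc1OC` gives 24 mg/kg in this assay

These three compounds share one core and differ only in what sits on a saturated chain carbon bound to a carbonyl carbon. Compound 3 does not stand apart from the other two on these numbers. The data show a 1.9-fold lower number from compound 1 to compound 3 (0.28 log units; within the scatter) and a 1.3-fold lower number from compound 2 to compound 3 (0.10 log units; within the scatter) as its two steps, and a 1.5-fold lower number from compound 1 to compound 2 (0.19 log units; within the scatter) completes the set.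

The next compound is compound 4 `COc1ccccc1OCC1SCCN1C(=O)CC(=O)O`, which carries carboxy in place of (ethoxycarbonyl)methyl on a saturated chain carbon bound to a carbonyl carbon in comparison with compound 3.

Among the compounds with values here, no measured step introduces carboxy, so the data offer only indirect guidance. The closest evidence is a 1.3-fold lower number from compound 2 to compound 3 (0.10 log units; within the scatter) at this same place, and a change there has so far stayed small. A modest move toward a higher number is therefore expected in this assay, though one that stays within the scatter. This estimate means an expected 1.5-fold higher number from compound 3 to compound 4 (0.18 log units; within the scatter) as the working figure. The estimated value for compound 4 is 36 mg/kg with an expected range from 14 mg/kg to 90 mg/kg because carboxy is new to this series.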

Compound 4, dose for half-maximal effect: 20 mg/kg
Compound 4: the middle estimate sits 1.8-fold (0.26 log units) above what was measured; the measured number falls inside the stated range.
By their numbers in this assay, from the lowest: compounds 4, 3, 2 and 1 (each within the scatter of the next, the first and the last beyond it).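

Carboxy at this place, on a saturated chain carbon bound to a carbonyl carbon, brings in a hydrogen-bond donor for the first time in this set, yet in this assay the swap from (ethoxycarbonyl)methyl gives only a small step (a 1.2-fold lower number from compound 3 to compound 4 (0.08 log units; within the scatter)), and the comparison with the acetyl compound, where hydroxy replaces methyl on a carbonyl carbon, looks much the same (a 1.5-fold lower number from compound 2 to compound 4 (0.18 log units; within the scatter)). Compared with the plain acetamide, however, adding carboxy gives the only step in the set that clears the scatter, though modestly (a 2.3-fold lower number from compound 1 to compound 4 (0.36 log units; beyond the scatter)), while compounds 2 and 3 each stay within the scatter of compound 1 and within the scatter of compound 4. No measurement at hand explains why such different groups give such close numbers at this place.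

The compounds shown leave open whether an amine or a primary amide at this place would stay with these four or move clearly away from them. They also leave open how a longer chain ending in a carboxylic acid, such as 2-carboxyethyl, would compare with the carboxymethyl chain of compound 4.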